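This account rests on a few compounds, and the source may have more. Where it says the series, first, only, none or still open, it means among the compounds named here.

The three compounds measured so far, with their results in a toxicity assay on HaCaT cells (Homo sapiens) for cytotoxicity, tested at 125 uM; a higher number here means a weaker effect of the compound at the concentration tested, a lower number a stronger effect:

compound 1 `O=S(=O)(Nc1nnc(SCc2ccccc2)s1)c1ccccc1` gives 84%
compound 2 `O=S(=O)(Nc1nnc(SCc2ccc(Cl)cc2)s1)c1ccccc1` gives 89%
compound 3 `Cc1ccc(S(=O)(=O)Nc2nnc(SCc3ccccc3)s2)cc1` gives 83%

Compound 3 gives the lowest of the three numbers, yet nothing separates it from its companions: the step of a number 1 percentage points lower from compound 1 to compound 3 (within the scatter) is within the scatter, and the gap to compound 2 is also no larger than the usual scatter of this assay, so all three compounds behave alike at the concentration tested.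

The next compound, compound 4 `Cc1ccc(S(=O)(=O)Nc2nnc(SCc3ccc(Cl)cc3)s2)cc1`, differs from compound 3 in one place: chloro in place of hydrogen on an aromatic carbon. The same change, made on the same benzyl ring in a pair otherwise alike, has already been measured once, as the step of a number 5 percentage points higher from compound 1 to compound 2 (within the scatter), which stayed within the scatter. Within the data shown here, with only that one step to go by, the expectation is that the change from compound 3 to compound 4 will again move the number little or not at all, that is a number 4 percentage points higher from compound 3 to compound 4 (within the scatter), which lies within the scatter.

Compound 4 is therefore expected to give about 87% in this assay, with a range from 77% to 97%.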

Compound 4, a percentage reported as activity, at one concentration (the size of the read-out at that concentration, not a potency): 85%
For compound 4 the middle estimate is 2 percentage points above the measured one, within the range that was stated.
By their numbers in this assay, from the lowest: compounds 3, 1, 4 and 2 (each within the scatter of the next).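

In this assay the chloro change now has a second reading on a different core, a number 2 percentage points higher from compound 3 to compound 4 (within the scatter), and the two readings agree: the same change on two cores in this assay, a number 5 percentage points higher (within the scatter) from compound 1 to compound 2 and a number 2 percentage points higher (within the scatter) from compound 3 to compound 4, 3 percentage points apart, within the scatter of two such steps. Compound 4 also gives a second reading of the methyl change, this time with the 4-chlorobenzyl group already in place, a number 4 percentage points lower from compound 2 to compound 4 (within the scatter), and this too agrees with the earlier reading: the same change on two cores in this assay, a number 1 percentage points lower (within the scatter) from compound 1 to compound 3 and a number 4 percentage points lower (within the scatter) from compound 2 to compound 4, 3 percentage points apart, within the scatter of two such steps. Each change therefore stays within the scatter whichever form the other part of the molecule takes, so across these four compounds neither change shows any dependence on the other.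

Only chloro and methyl are shown, which leaves open whether an amine, a carboxylic acid or a longer chain in place of the same hydrogens would also leave the number unmoved. From the compounds shown here alone, the read-out comes from one concentration and gives the size of the effect there rather than a potency, so whether these compounds would still look alike at other concentrations remains unknown.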